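A few compounds are considered here, and "the series" means these few. Any claim that something is new, unique, unknown or untested is made for them only; others in the source may bear on it.

Measured so far:
- compound 1 `Cc1nc(C(NC(=O)C(=O)Nc2ccc(Cl)cc2)C2CCNCC2)sc1CCO`: > 78500 nM
- compound 2 `Cc1nc(C(NC(=O)C(=O)Nc2ccc(F)cc2)C2CCCCN2)sc1CO`: > 113000 nM

In an ADME assay on MT2 cells (Homo sapiens) for cytotoxicity, read by XTT assay, with a stated time of 4 days (on this read-out higher numbers stand for lower toxicity in this test and lower numbers for higher toxicity in this test), compound 1 gives > 78500 nM, a limit of the assay rather than a number. Compound 2 likewise gives > 113000 nM, also a limit. Compound 1 therefore stands at a limit (the limit of > 78500 nM in this assay, at which 1 of the 2 values shown sits), and the other value shown is a limit as well (the limit of > 113000 nM in this assay, at which 1 of the 2 values shown sits). Compound 3 `Cc1nc(C(NC(=O)C(=O)Nc2ccc(Cl)cc2)C2CCCCN2)sc1CCO` is not yet measured; it differs from compound 1 by piperidin-2-yl in place of piperidin-4-yl on a saturated chain carbon bound to an amide-type nitrogen and an aromatic carbon. Going by the values given here, no measured step is available, so the expected step that the limit leaves unreadable from compound 1 to compound 3 is none beyond the usual scatter. Compound 3 is expected to give 100000 nM, likely between 40000 nM and 300000 nM.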

Compound 3, half-maximal cytotoxic concentration: > 62000 nM
Compound 3 was reported as a limit (the forecaster's own chance of this, stated with the estimate: 85%); the middle value lies beyond the limit too.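

Going by these compounds alone, compound 1 and compound 3 are both reported as limits rather than numbers, so no step between them can be read. Going by these compounds, whether piperidin-2-yl in place of piperidin-4-yl changes cytotoxicity at all remains open.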